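A few compounds are considered here, and "the series" means these few. Any claim that something is new, unique, unknown or untested is made for them only; others in the source may bear on it.

Working notes on an in vivo ADME assay on the whole organism (strain Sprague-Dawley) for pharmacokinetics, with Rattus norvegicus as the target, at a dose of 2 mg/kg by the intravenous route; on this read-out higher numbers stand for higher exposure at the dose given and lower numbers for lower exposure. Of the compounds shown here, two have been measured so far. Compound 1 (`O=C(CC(c1ccccc1)c1ccccc1)N1CCN(C(c2ccccc2)c2cccc(Cl)c2)CC1`) gives 2550 nM, and compound 2 (`O=C(NC(c1ccccc1)c1ccccc1)N1CCN(C(c2ccccc2)c2ccccc2)CC1`) gives 2930 nM. These two values lie within the usual scatter of each other, so neither stands apart from the other on the numbers available. Within the data shown here, no step between compounds differing in one place has been measured, which leaves nothing to calibrate the next change against.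

Compound 3 (`O=C(CC(c1ccccc1)c1ccccc1)N1CCN(C(c2ccccc2)c2cccc(C(F)(F)F)c2)CC1`) keeps the core of compound 1 and carries a single change: trifluoromethyl in place of chloro on an aromatic carbon. This is trifluoromethyl in place of chloro on an aromatic carbon, turning the 3-chlorophenyl into a 3-(trifluoromethyl)phenyl. The expectation therefore rests on compound 1 at 2550 nM, with no shift beyond the scatter anticipated and no direction favoured. The expected change is a 1.0-fold lower number from compound 1 to compound 3 (0.01 log units; within the scatter). For compound 3 the estimated value is 2500 nM, with an expected range from 1300 nM to 4800 nM.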

Compound 3, maximal plasma concentration in the Rattus norvegicus assay: 2540 nM
Compound 3: the middle estimate sits 1.0-fold (0.01 log units) below what was measured; measured number inside the range.
By their numbers in the Rattus norvegicus assay, from the lowest: compounds 3, 1 and 2 (each within the scatter of the next).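

Among these compounds, in the Rattus norvegicus assay, this is the first step that can be read: trifluoromethyl in place of chloro on an aromatic carbon, meta to a large group, gives a 1.0-fold lower number from compound 1 to compound 3 (0.00 log units; within the scatter). At this position, then, going from one heavy atom to four, with no hydrogen-bond donor or acceptor on either side, leaves maximal plasma concentration without a shift that can be told from the scatter. In a physicochemical assay for solubility, at pH 7.4 (on this read-out higher numbers stand for higher solubility and lower numbers for lower solubility), compound 1 gives 0.37 ug/mL and compound 3 gives 0.14 ug/mL. This single pair also shows that the two read-outs need not move together at this position, since the same change in the physicochemical assay gives a step beyond the scatter: the measured solubility of compound 1, 0.37 ug/mL, and of compound 3, 0.14 ug/mL, a 2.6-fold lower number (0.42 log units; beyond the scatter)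

The compounds shown leave open whether a different kind of group at this position, such as an amine, a carboxylic acid or a nitrile, would move maximal plasma concentration or solubility, or whether the two read-outs would again part. One pair also cannot tell whether the same exchange would give the same outcome at another place on the shared core, or why exposure and solubility parted here.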